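Acetylation of the core hydroxy group in the benzoate series

A few compounds are considered here, and "the series" means these few. Any claim that something is new, unique, unknown or untested is made for them only; others in the source may bear on it.

Compound 1 `CC(=O)O[C@H]1/C=C(/C)[C@H](OC(=O)c2ccccc2)C/C=C(\C)CCCC1(C)C` carries an acetoxy group on the shared core together with a plain benzoate ester. In a functional assay on K562 cells (Homo sapiens) for cytotoxicity, read by MTT assay (on this read-out higher numbers stand for weaker inhibition and lower numbers for stronger inhibition), compound 1 gives only a limit, > 50000 nM. Compound 2 `C/C1=C/[C@H](O)C(C)(C)CCC/C(C)=C/C[C@H]1OC(=O)c1ccc(O)cc1` instead carries a free hydroxy group on the core and a hydroxybenzoate ester. In this assay compound 2 likewise gives only a limit, > 50000 nM. Compound 2 therefore stands at the same limit as the other value shown, (the limit of > 50000 nM in this assay, at which 2 of the 2 values shown sit), and no number separates the two compounds; nothing about order or size can be read from this pair. Among the compounds with values here, no step between measured compounds is available, so no measured change gives a direction for the next move.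

Compound 3 `CC(=O)O[C@H]1/C=C(/C)[C@H](OC(=O)c2ccc(O)cc2)C/C=C(\C)CCCC1(C)C` is the compound still to be measured in this assay. It differs from compound 2 by acetyl in place of hydrogen on an oxygen on a saturated carbon. As both measured compounds sit at the limit, the expected step that the limit leaves unreadable from compound 2 to compound 3 is none beyond the scatter. Compound 3 is expected to give 60000 nM, within 20000 nM to 200000 nM, most likely again reported only as a limit.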

Compound 3, half-maximal inhibitory concentration: 33000 nM
Beside the measured number, compound 3's estimate is 1.8-fold (0.26 log units) above it; low and high end bracket the measured number.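

In this assay, within the data shown here, compound 3 gives 33000 nM, the first real number, and it carries both the acetoxy group on the shared core and the hydroxy group on the aromatic ring of the benzoate. Each single change can now be given a direction, though only as a floor: acetyl in place of hydrogen on an oxygen on a saturated carbon gives an at least 1.5-fold lower number from compound 2 to compound 3 (0.18 log units; that floor lies within the scatter), and hydroxy in place of hydrogen on an aromatic carbon gives an at least 1.5-fold lower number from compound 1 to compound 3 (0.18 log units; that floor lies within the scatter). Neither floor shows a change beyond the scatter, and the full size of each step cannot be read, since only the number for compound 3 is a measured value: the limit of > 50000 nM in this assay, at which 2 of the 3 values shown sit.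

Still open, as far as these compounds go, is whether either step is really larger than its floor, and so whether either group matters on its own or only the two together. Also open, from the compounds shown here alone, is how this assay would respond to a longer chain such as butanoyl in place of acetyl on that oxygen, or to an amine in place of the hydroxy group on the aromatic carbon.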